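Trading a methoxyphenyl for a difluorophenyl: compound 4

The source may report more compounds than this note shows. Statements on the series, on what has been measured and on what is new or still open speak of the compounds shown alone.

Compound 1 `CC(C)N1CCN(Cc2csc(N)c2C(=O)c2ccc(Cl)cc2)CC1` gives 0% in an assay on CHO cells for displacement of a labelled ligand from adenosine receptor A3 (Homo sapiens), read by scintillation counting, with a stated time of 120 min, tested at 10 uM; on this read-out lower numbers stand for less inhibition and higher numbers for more inhibition at the one concentration tested (going by the name of the read-out). Compound 2 `COc1ccc(N2CCN(Cc3csc(N)c3C(=O)c3ccc(Cl)cc3)CC2)cc1` gives 0%. Compound 3 `Nc1scc(CN2CCN(c3cccc(F)c3)CC2)c1C(=O)c1ccc(Cl)cc1` gives 4%.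

Compound 2 stands level with compound 1 at the digits shown, the two together being the lowest of the three numbers; the step of a number 4 percentage points higher from compound 2 to compound 3 (within the scatter) is within the scatter. The change to compound 4 `Nc1scc(CN2CCN(c3ccc(F)c(F)c3)CC2)c1C(=O)c1ccc(Cl)cc1` is 3,4-difluorophenyl in place of 4-methoxyphenyl on an amine nitrogen in a ring. Three earlier steps swap groups on the same ring nitrogen: no change at the digits printed from compound 1 to compound 2 (within the scatter), a number 4 percentage points higher from compound 1 to compound 3 (within the scatter) and a number 4 percentage points higher from compound 2 to compound 3 (within the scatter), none beyond the scatter. Because the step of a number 4 percentage points higher from compound 2 to compound 3 (within the scatter) stays within the scatter, the step of a number 3 percentage points higher from compound 2 to compound 4 (within the scatter) is expected to lie within the scatter as well. Compound 4 is therefore estimated at 3%, with a range from -5% to 12%.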

Compound 4, a percentage reported as inhibition, at one concentration (the size of the read-out at that concentration, not a potency): 1%
Compound 4: the middle estimate sits 2 percentage points above what was measured; low and high end bracket the measured number.
By their numbers in this assay, from the lowest: compounds 1, 2, 4 and 3 (each within the scatter of the next).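

In this assay, 3,4-difluorophenyl in place of 4-methoxyphenyl gives a number 1 percentage points higher from compound 2 to compound 4 (within the scatter) and in place of isopropyl gives a number 1 percentage points higher from compound 1 to compound 4 (within the scatter) so this new group on the ring nitrogen leaves the read-out where the earlier groups put it. Fluoro in place of hydrogen on an aromatic carbon gives a number 3 percentage points lower from compound 3 to compound 4 (within the scatter) so this added fluoro also makes no difference beyond the scatter. No measurement here explains these numbers.

On these data alone, whether a carboxylic acid, an amine or a longer chain on this nitrogen would move the read-out stays open.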